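Pyrazole to triazole on the amide nitrogen

A few compounds are considered here, and "the series" means these few. Any claim that something is new, unique, unknown or untested is made for them only; others in the source may bear on it.

Three compounds with the shared core carry different benzyl substituents. Compound 1 `Cn1ccc(NC(=O)c2cn(Cc3cccc(OC(F)(F)F)c3)cn2)n1` gives 32 nM in an assay for inhibition of acyl-CoA desaturase 1 (Rattus norvegicus); on this read-out higher numbers stand for weaker inhibition and lower numbers for stronger inhibition; compound 2 `Cn1ccc(NC(=O)c2cn(Cc3cccc(Cl)c3)cn2)n1` gives 57 nM; compound 3 `Cn1ccc(NC(=O)c2cn(Cc3ccc(Cl)c(C(F)(F)F)c3)cn2)n1` gives 16 nM. Among the compounds with values here, the one single-point step among them, a 1.8-fold higher number from compound 1 to compound 2 (0.25 log units; within the scatter), lies on the benzyl aromatic ring. Compound 3 holds the lowest of the three numbers: its gap to compound 1 is within the scatter, its gap to compound 2 is beyond it.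

Compound 4 `Cn1cnc(NC(=O)c2cn(Cc3ccc(Cl)c(C(F)(F)F)c3)cn2)n1` differs from compound 3 by 1-methyl-1H-1,2,4-triazol-3-yl in place of 1-methyl-1H-pyrazol-3-yl on an amide-type nitrogen. Within the data shown here, no measured step touches this part of the molecule; the only step known, from compound 1 to compound 2, concerns the benzyl ring and says nothing about the amide side. With nothing to point in either direction, the step of a 1.3-fold higher number from compound 3 to compound 4 (0.10 log units; within the scatter) in this assay is expected to stay within the scatter, with a wide range to cover the unknown. Compound 4 is therefore estimated at 20 nM, between 6 nM and 65 nM.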

Compound 4, half-maximal inhibitory concentration: 63 nM
Beside the measured number, compound 4's estimate is 3.2-fold (0.50 log units) below it; measured number inside the range.
By their numbers in this assay, from the lowest: compounds 3, 1, 2 and 4 (each within the scatter of the next, the first and the last beyond it).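

In this assay, within the data shown here, the amide side of the shared core proves sensitive: a 3.9-fold higher number from compound 3 to compound 4 (0.60 log units; beyond the scatter) is beyond the scatter, whereas the only earlier single-point step, a 1.8-fold higher number from compound 1 to compound 2 (0.25 log units; within the scatter) on the benzyl ring, stayed within it. The exchange is small on paper, with the heavy-atom count unchanged and a nitrogen taking the place of a carbon in the five-membered aromatic ring, yet it moves the number in the direction of weaker inhibition. No data shown here bear on what lies behind this step.

As far as these compounds go, whether the same exchange gives a similar step on the benzyl groups of compound 1 and compound 2 remains open. Also open, from the compounds shown here alone, is how a phenyl group on the amide-type nitrogen, or an ethyl group in place of the ring methyl, would read out.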